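Catechol Diether Amides as Phosphodiesterase Inhibitors

A few compounds are considered here, and "the series" means these few. Any claim that something is new, unique, unknown or untested is made for them only; others in the source may bear on it.

Measured compounds:
compound 1 `COc1ccc(C(=O)Nc2cccc(Cl)c2Cl)cc1OC1CCCC1` gives > 200000 nM
compound 2 `COc1ccc(C(=O)Nc2ccccc2C(=O)c2ccccc2)cc1OC1CCCC1` gives 1700 nM

The study concerns two amides built on a shared core, tested in an assay on isolated protein for inhibition of phosphodiesterase 4A (Sus scrofa); a lower number here means a stronger inhibitor, a higher number a weaker inhibitor. Compound 1 `COc1ccc(C(=O)Nc2cccc(Cl)c2Cl)cc1OC1CCCC1` reaches only a limit of the assay in this assay, > 200000 nM, so no number is known for it; it sits at the limit of > 200000 nM in this assay, at which 1 of the 2 values shown sits. Compound 2 `COc1ccc(C(=O)Nc2ccccc2C(=O)c2ccccc2)cc1OC1CCCC1` gives 1700 nM in this assay, a measured figure rather than a limit. Among the measured compounds shown here, no single-point step between the two measured compounds is available, so the data show only their two values.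

The unmeasured compound 3 `COc1ccc(C(=O)Nc2nccs2)cc1OC1CCCC1` differs from compound 1 in one place: 1,3-thiazol-2-yl in place of 2,3-dichlorophenyl on an amide-type nitrogen. The change replaces a carbocyclic aromatic ring on the amide-type nitrogen with a smaller heteroaromatic one. With compound 1 known only as a limit, the step from compound 1 to compound 3 cannot be anchored on a number, and the expectation rests on compound 2 showing that a measurable value is possible on this core. The expected step of an at least 10-fold lower number from compound 1 to compound 3 (1.00 log units; beyond the scatter) is toward stronger inhibition, with wide uncertainty. Compound 3 is estimated at 20000 nM, between 3000 nM and 150000 nM.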

Compound 3, half-maximal inhibitory concentration: 6500 nM
For compound 3 the middle estimate is 3.1-fold (0.49 log units) above the measured one, within the range that was stated.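

Within this assay, putting 1,3-thiazol-2-yl in place of 2,3-dichlorophenyl on an amide-type nitrogen gives an at least 30-fold lower number from compound 1 to compound 3 (1.48 log units; beyond the scatter), the only step between compounds that differ in one place. It shows that the group on this nitrogen alone can decide whether the shared core gives a measured number or only a limit, and that a carbocyclic aromatic ring is not required there for a measurable value. Compound 1 gives > 200000 nM, which is a limit of the assay and not a number, so the size of the step is known only as a bound: the limit of > 200000 nM in this assay, at which 1 of the 3 values shown sits.

The entering group differs from the leaving one at once in ring size, in its ring atoms, in its hydrogen-bond acceptors and in the absence of both chlorines, and this single step cannot separate these differences. From the compounds shown here alone, it also remains open how an unsubstituted phenyl or a pyridine ring on the same nitrogen would compare with compound 3, or what a carboxylic acid or an amine attached to the 1,3-thiazol-2-yl ring would do.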